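The source may report more compounds than this note shows. Statements on the series, on what has been measured and on what is new or still open speak of the compounds shown alone.

Compound 1 `CC(C)c1nc(SCc2ccc(-c3ccccc3C#N)cc2)c2ccccc2n1`: > 100000 nM
Compound 2 `COC(=O)c1ccccc1-c1ccc(CSc2nc(C(C)C)nc3ccccc23)cc1`: > 100000 nM
Compound 3 `COC(=O)c1cccc(-c2ccc(CSc3nc(C(C)C)nc4ccccc34)cc2)c1`: > 100000 nM

In an assay on isolated protein for inhibition of phosphodiesterase 7 (Homo sapiens), read by scintillation proximity assay and cAMP accumulation, with a stated time of 1 h (on this read-out lower numbers stand for stronger inhibition and higher numbers for weaker inhibition), compound 3 gives > 100000 nM, which is a limit of the assay and not a number. Compound 1 and compound 2 sit at the same limit, so all three measured compounds fall under the limit of > 100000 nM in this assay, at which 3 of the 3 values shown sit, and none of them is placed on the scale. The three steps among them are therefore unreadable: the change from compound 1 to compound 2 gives a step that the two limits leave unreadable from compound 1 to compound 2, the change from compound 1 to compound 3 gives a step that the two limits leave unreadable from compound 1 to compound 3, and the change from compound 2 to compound 3 gives a step that the two limits leave unreadable from compound 2 to compound 3.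

Compound 4 `COC(=O)c1ccc(-c2ccc(CSc3nc(C(C)C)nc4ccccc34)cc2)cc1` differs from compound 3 in one place: 4-(methoxycarbonyl)phenyl in place of 3-(methoxycarbonyl)phenyl on an aromatic carbon. The measured steps that bear on this change, the moves of the methoxycarbonyl group around the outer phenyl ring from compound 1 to compound 3 and from compound 2 to compound 3, could not be sized because all three measured values sit at the limit of > 100000 nM in this assay, at which 3 of the 3 values shown sit. The step from compound 3 to compound 4 is therefore expected to be a number no higher from compound 3 to compound 4 (the limit leaves the size open), with compound 4 most likely also reported only as a limit in this assay. Compound 4 is estimated at 100000 nM in this assay, within a range from 30000 nM to 300000 nM.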

Compound 4, half-maximal inhibitory concentration: 33000 nM
Estimate against measurement, compound 4: 3.0-fold (0.48 log units) above; the measured number falls inside the stated range.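

Among these compounds, changing 3-(methoxycarbonyl)phenyl to 4-(methoxycarbonyl)phenyl is the first change here to bring a compound onto the scale of this assay, giving an at least 3.0-fold lower number from compound 3 to compound 4 (0.48 log units; beyond the scatter). The same group, in place of 2-(methoxycarbonyl)phenyl, gives an at least 3.0-fold lower number from compound 2 to compound 4 (0.48 log units; beyond the scatter), and in place of 2-cyanophenyl it gives an at least 3.0-fold lower number from compound 1 to compound 4 (0.48 log units; beyond the scatter). The outer ring is therefore sensitive to where the methoxycarbonyl group sits, even with the same atoms joined differently, yet compound 4 is the only compound placed on the scale, and the other three remain at a limit of the assay: the limit of > 100000 nM in this assay, at which 3 of the 4 values shown sit.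

On these data alone, the steps among compound 1, compound 2 and compound 3 cannot be read, and the full size of each new step remains open, with only its minimum known. As far as these compounds go, it also remains open whether the gain depends on the methoxycarbonyl group itself, or whether a carboxylic acid, a primary amide or an amine on the same ring carbon would give a lower or a higher number in this assay.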